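This account rests on a few compounds, and the source may have more. Where it says the series, first, only, none or still open, it means among the compounds named here.

Compound 1 `COc1ccc(-c2cc(/C=C/C(=O)c3ccc(N)cc3)[nH]n2)cc1` and compound 2 `COc1cc(-c2cc(/C=C/C(=O)c3ccc(Cl)c(Cl)c3)[nH]n2)cc(OC)c1OC` share a core. In a functional assay on CCRF-CEM cells (Homo sapiens) for cytotoxicity, read by sulforhodamine B assay, with a stated time of 48 h, tested at 0.1 uM (a higher number here means a weaker effect of the compound at the concentration tested, a lower number a stronger effect), compound 1 gives 98% and compound 2 gives 98%, so compound 2 stands level with compound 1 within the scatter, and both show only a weak effect at the concentration tested. Compound 3 `COc1ccc(C(=O)/C=C/c2cc(-c3cc(OC)c(OC)c(OC)c3)n[nH]2)cc1` differs from compound 2 in one place: 4-methoxyphenyl in place of 3,4-dichlorophenyl on a carbonyl carbon. Among the measured compounds shown here, no measured pair shows what this swap does, and the step of a number 1 percentage points lower from compound 2 to compound 3 (within the scatter) is expected to be none beyond the scatter. Compound 3 is therefore estimated to give about 97% in this assay, within a range from 85% to 102%.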

Compound 3, a percentage reported as activity, at one concentration (the size of the read-out at that concentration, not a potency): 98%
Compound 3: middle estimate off by 1 percentage points, on the low side; the range from low to high includes it.
By their numbers in this assay, from the lowest: compounds 1, 2 and 3 (each within the scatter of the next).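

In this assay, among the compounds shown here, 4-methoxyphenyl in place of 3,4-dichlorophenyl on a carbonyl carbon gives no change at the digits printed from compound 2 to compound 3 (within the scatter), the first direct one-place comparison in this set. At this single concentration the two groups cannot be told apart, but both compounds show only a weak effect, so this does not show that the swap would make no difference at other concentrations. Nothing available explains the result. Still open, as far as these compounds go, is what a carboxylic acid on this ring, or a longer chain on the carbonyl carbon in place of the ring, would do.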